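The source may hold more compounds than are shown below. What is called first, only, known or untested is meant among the compounds shown, and "the series" means these compounds.

Measured compounds:
compound 1 `Cc1cn(C2CCN(Cc3cccc(Oc4ccncc4)c3)CC2)c(=O)[nH]c1=O`: "not determined" (no result reported)
compound 2 `Cc1cn(C2CCN(Cc3cccc(Oc4cccc(F)c4)c3)CC2)c(=O)[nH]c1=O`: > 64000 nM

In an ADME assay on MRC5 cells (Homo sapiens) for cytotoxicity, read by fluorescence and resazurin assay, with a stated time of 3 days (on this read-out lower numbers stand for stronger inhibition and higher numbers for weaker inhibition), compound 1 has "not determined" (no result reported), so no number stands for it. For compound 2 the result is only a limit of the measurement, > 64000 nM, which is the limit of > 64000 nM in this assay, at which 1 of the 2 values shown sits. Compound 3 `Cc1cn(C2CCN(Cc3cccc(Oc4ccc(Cl)c(Cl)c4)c3)CC2)c(=O)[nH]c1=O` has not been measured yet. It differs from compound 2 by 3,4-dichlorophenyl in place of 3-fluorophenyl on an oxygen on an aromatic ring. For the measured compounds named here, no step between two measured compounds is available to set a size, so the step of an at least 1.0-fold lower number from compound 2 to compound 3 (0.02 log units; that floor lies within the scatter) is expected to stay within the usual scatter, in no particular direction. Compound 3 is therefore estimated at 60000 nM, between 20000 nM and 150000 nM.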

Compound 3, half-maximal inhibitory concentration: 6100 nM
Beside the measured number, compound 3's estimate is 9.8-fold (0.99 log units) above it; the measured number lies below the stated range.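

In this assay, the group on the oxygen clearly matters: 3,4-dichlorophenyl in place of 3-fluorophenyl gives an at least 10-fold lower number from compound 2 to compound 3 (1.02 log units; beyond the scatter). Compound 3 is thus the first compound shown with a single number, so a change at this position alone can bring cell toxicity into the measurable range. The value of compound 2 is only a limit: the limit of > 64000 nM in this assay, at which 1 of the 3 values shown sits.

The compounds shown do not separate the effect of removing fluorine from that of adding either chlorine. On these data alone, how a phenyl ring carrying an amine or a carboxylic acid would read also stays open.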